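The source may report more compounds than this note shows. Statements on the series, on what has been measured and on what is new or still open speak of the compounds shown alone.

Of the compounds shown here, two built on the same core have been measured so far, and their numbers lie close together. In a functional assay on MCF7 cells (Homo sapiens) for inhibition, read by CCK-8 assay, with a stated time of 48 h (on this read-out higher numbers stand for weaker inhibition of growth and lower numbers for stronger inhibition of growth), compound 1 (`Cc1ccc(Nc2nc(Nc3ccc(N4CCN(C)CC4)cn3)ncc2Cl)cc1`) gives 11400 nM and compound 2 (`CN1CCN(c2ccc(Nc3ncc(Cl)c(Nc4ccc(C(C)(C)C)cc4)n3)nc2)CC1`) gives 12600 nM as its value, so compound 2 stands level with compound 1 and not apart from it. The next compound to be measured, compound 3 (`Cc1cc(C)c(Nc2nc(Nc3ccc(N4CCN(C)CC4)cn3)ncc2Cl)c(C)c1`), keeps that core and changes one group: 2,4,6-trimethylphenyl in place of 4-(tert-butyl)phenyl on a nitrogen on an aromatic ring (in full: 2,4,6-trimethylphenyl in place of 4-(tert-butyl)phenyl on a nitrogen on an aromatic ring). Among the compounds with values here, the one measured step that bears on this, a 1.1-fold higher number from compound 1 to compound 2 (0.04 log units; within the scatter), put tert-butyl in place of methyl on an aromatic carbon and stayed within the scatter. Neither measured compound carries 2,4,6-trimethylphenyl, so this is thin evidence, but it points in neither direction. No step beyond the scatter is therefore expected in this assay, and the estimated change is a 1.1-fold lower number from compound 2 to compound 3 (0.06 log units; within the scatter) as a best guess. Compound 3 is expected at 11000 nM, with a likely range from 4000 nM to 30000 nM given how little has been measured.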

Compound 3, concentration for 50% growth inhibition: 9470 nM
Compound 3: the middle estimate sits 1.2-fold (0.07 log units) above what was measured; low and high end bracket the measured number.
By their numbers in this assay, from the lowest: compounds 3, 1 and 2 (each within the scatter of the next).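

With compound 3, the change on this nitrogen goes beyond a single group on the phenyl ring. 2,4,6-trimethylphenyl carries three methyl groups where 4-(tert-butyl)phenyl and 4-methylphenyl carry one. In this assay, this exchange gives a 1.3-fold lower number from compound 2 to compound 3 (0.12 log units; within the scatter) and the exchange for the smaller 4-methylphenyl gives a 1.2-fold lower number from compound 1 to compound 3 (0.08 log units; within the scatter) so neither step separates compound 3 from the earlier two, and all three compounds read alike at this position despite the different arrangement of carbon groups on the ring. No measurement is available here that could explain this lack of separation.

As far as these compounds go, the three compounds all place a phenyl ring carrying only carbon groups on this nitrogen, so it remains open whether an amine or a carboxylic acid on that ring would move the number beyond the scatter. From the compounds shown here alone, it also remains open whether a longer chain in place of the ring would do so, or whether this position can change the growth read-out at all.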